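The compounds below may be only part of what the source reports. "The series", "measured", "known", "first", "only" and "open" are said of these compounds alone.

Measured compounds and their values:

In a functional assay for agonist activity at G protein-coupled receptor 88 (Homo sapiens), read by HTRF and cAMP accumulation (a higher number here means that more compound is needed for the effect, a lower number that less compound is needed), compound 1 `CC[C@H](C)[C@H](N)CN(C(=O)[C@@H]1C[C@H]1c1ccccc1)c1ccc(-c2ccccc2)cc1` gives 230 nM; 800 nM (2 entries).
Compound 2 `CCOc1ccc(-c2ccc(N(C[C@@H](N)[C@@H](C)CC)C(=O)[C@@H]3C[C@H]3c3ccccc3)cc2)cc1` gives 90 nM.
Compound 3 `CC[C@H](C)[C@H](N)CN(C(=O)[C@@H]1C[C@H]1c1ccccc1)c1ccc(-c2ccc(Oc3ccccc3)cc2)cc1` gives 94 nM.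

Compound 3 stands at the highest of the two single numbers, yet its nearest neighbour compound 2 lies within the scatter of it, as the step of a 1.0-fold higher number from compound 2 to compound 3 (0.02 log units; within the scatter) shows; compound 1 has two entries that differ between themselves the several entries of compound 1 in this assay, 230 nM; 800 nM (2 entries) and so gives no single number. Compound 4 `CC[C@H](C)[C@H](N)CN(C(=O)[C@@H]1C[C@H]1c1ccccc1)c1ccc(-c2ccc(CO)cc2)cc1` differs from compound 3 in one place: hydroxymethyl in place of phenoxy on an aromatic carbon. Going by the values given here, the only measured step that touches this position, a 1.0-fold higher number from compound 2 to compound 3 (0.02 log units; within the scatter), exchanged one oxygen-linked group for another and stayed within the scatter. Among the compounds with values here, no measured step exchanges such a group for a hydroxymethyl. Compound 1, which carries no group on that ring, gives 230 nM; 800 nM (2 entries), so the weaker end of the series is marked by it. Compound 4 is therefore expected to show a 2.1-fold higher number from compound 3 to compound 4 (0.33 log units; beyond the scatter), toward a higher number but not far. The estimate for compound 4 is 200 nM, with a range from 60 nM to 700 nM.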

Compound 4, half-maximal effective concentration: 1100 nM
The estimate for compound 4 lay 5.5-fold (0.74 log units) below the measured number, outside the stated range (above it).
By their numbers in this assay, from the lowest: compounds 2 and 3 (each within the scatter of the next); then compound 4.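

In this assay the step of a 1.0-fold higher number from compound 2 to compound 3 (0.02 log units; within the scatter) had made this position look indifferent to what stands on its oxygen, but that exchange only swapped ethoxy and phenoxy. Hydroxymethyl shows that the position does respond, with a 12-fold higher number from compound 3 to compound 4 (1.07 log units; beyond the scatter) and a 12-fold higher number from compound 2 to compound 4 (1.09 log units; beyond the scatter) both large. Compound 4, with its group on that aromatic carbon, even lies above both values of compound 1, which carries no group there: the several entries of compound 1 in this assay, 230 nM; 800 nM (2 entries).

The compounds shown cannot separate the loss of the ring from the arrival of the hydroxyl hydrogen, since hydroxymethyl differs from phenoxy and ethoxy in more than one way. On these data alone, whether a methoxy group, a longer chain ending in a hydroxyl, an amine or a carboxylic acid would fall near compound 2 or near compound 4 stays open.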